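Carbamoyl to aminomethyl exchange: expected clearance of compound 4

The source may report more compounds than this note shows. Statements on the series, on what has been measured and on what is new or still open speak of the compounds shown alone.

Compound 3 `NC(=O)CNC(=O)C[C@@H]1CCC[C@]2(C1)OOC1(O2)C2CC3CC(C2)CC1C3` was measured in an ADME assay on microsomes from liver (Mus musculus) for metabolic stability (on this read-out lower numbers stand for slow clearance and higher numbers for fast clearance), and gives 18.6 uL/min. Compound 1 `O=C(C[C@H]1CC[C@]2(CC1)OO[C@]1(O2)C2CC3CC(C2)CC1C3)N1CCNCC1` gives 14.4 uL/min, which stands within the scatter of compound 3; compound 2 `NC1CCN(C(=O)C[C@H]2CC[C@]3(CC2)OO[C@]2(O3)C3CC4CC(C3)CC2C4)CC1` gives 2.5 uL/min, and the gap from compound 3 to compound 2 is beyond the scatter. Compound 4 `CC(C)(CN)CNC(=O)C[C@@H]1CCC[C@]2(C1)OOC1(O2)C2CC3CC(C2)CC1C3` is not yet measured in this assay. The change is 1-(aminomethyl)-1-methylethyl in place of carbamoyl on a saturated chain carbon bound to an amide-type nitrogen. Among the compounds with values here, the one measured step with some bearing is a 5.8-fold lower number from compound 1 to compound 2 (0.76 log units; beyond the scatter), where a primary amine entered in place of a ring nitrogen; here a primary amine also enters, but in place of carbamoyl rather than a ring nitrogen, so the step is only loosely comparable. A modest move downward is therefore expected, smaller than the step from compound 1 to compound 2, and it may well remain within the scatter. The step expected from compound 3 to compound 4 is a 1.9-fold lower number from compound 3 to compound 4 (0.27 log units; within the scatter). Compound 4 is estimated at 10 uL/min, with a range from 4 uL/min to 25 uL/min.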

Compound 4, intrinsic clearance in a liver preparation (reported as CLH), per the amount of preparation that the assay uses: 10.8 uL/min
Beside the measured number, compound 4's estimate is 1.1-fold (0.03 log units) below it; low and high end bracket the measured number.
By their numbers in this assay, from the lowest: compound 2; then compounds 4, 1 and 3 (each within the scatter of the next).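

In this assay, the exchange of carbamoyl for 1-(aminomethyl)-1-methylethyl on a saturated chain carbon bound to an amide-type nitrogen gives a 1.7-fold lower number from compound 3 to compound 4 (0.24 log units; within the scatter). At this place, therefore, the larger amine-bearing group is tolerated without a step beyond the scatter, and compound 3 and compound 4 cannot be separated on this read-out. A primary amine entering the series does not by itself carry a step of the size seen in a 5.8-fold lower number from compound 1 to compound 2 (0.76 log units; beyond the scatter), which arose at a different place on a different parent. No measurement shown here accounts for this result.

The compounds shown leave open whether the amine or the branched chain governs the read-out at this place. A straight 2-aminoethyl chain and a carboxylic acid in place of carbamoyl would each test a separate part of that question.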